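This account rests on a few compounds, and the source may have more. Where it says the series, first, only, none or still open, it means among the compounds named here.

Working notes on the benzyl-ether series around the shared core. Compound 1 `COc1cc(OC)c(-c2coc3cc(OCc4ccccc4)ccc3c2=O)cc1OC` in a functional assay on U-251 cells (Homo sapiens) for antiproliferative activity, read by MTT assay, with a stated time of 24 h (a higher number here means a weaker inhibitor, a lower number a stronger inhibitor), gives 6750 nM. Compound 2 `COc1cc(OC)c(-c2coc3cc(OCc4ccc(Br)cc4)ccc3c2=O)cc1OC` differs by bromo in place of hydrogen on an aromatic carbon, and in this assay compound 2 gives 10000 nM; the step is a 1.5-fold higher number from compound 1 to compound 2 (0.17 log units; within the scatter). Compound 3 `COc1cc(OC)c(-c2coc3cc(OCc4ccccc4C#N)ccc3c2=O)cc1OC` in this assay gives 980 nM, reached from compound 1 by a 6.9-fold lower number from compound 1 to compound 3 (0.84 log units; beyond the scatter) and from compound 2 by a 10-fold lower number from compound 2 to compound 3 (1.01 log units; beyond the scatter). Compound 2 thus stands at the highest number of the three measured, with compound 1 within the scatter of it and compound 3 beyond it.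

The step under consideration runs from compound 2 to compound 4 `COc1cc(OC)c(-c2coc3cc(OCc4cccc(C(F)(F)F)c4)ccc3c2=O)cc1OC`. 3-(trifluoromethyl)phenyl in place of 4-bromophenyl on a saturated chain carbon bound to an oxygen on an aromatic ring Of the measured steps, only a 10-fold lower number from compound 2 to compound 3 (1.01 log units; beyond the scatter) also exchanges the whole aryl group on that carbon, and it was large; a 1.5-fold higher number from compound 1 to compound 2 (0.17 log units; within the scatter) shows that the bromo on compound 2 changes nothing beyond the scatter. Going by the values given here, no measured step bears on a trifluoromethyl group or on a 3-(trifluoromethyl)phenyl pattern, so the expectation rests on the single aryl swap. A lower number is expected, though well short of the step to compound 3. The expected step in this assay is a 2.0-fold lower number from compound 2 to compound 4 (0.30 log units; within the scatter). In this assay compound 4 is estimated at 5000 nM, with a range from 2000 nM to 12000 nM.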

Compound 4, half-maximal inhibitory concentration: > 10000 nM
Compound 4: a limit, no number; the forecaster's own chance of this, stated with the estimate: 5%; middle value at least 2.0-fold (0.30 log units) from the limit.
By their numbers in this assay, from the lowest: compound 3; then compounds 1 and 2 (each within the scatter of the next).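

In this assay compound 4 carries a limit of the assay and not a number: the limit of > 10000 nM in this assay, at which 1 of the 4 values shown sits. The step reads a number no lower from compound 2 to compound 4 (the limit leaves the size open). This shows that exchanging the whole aryl group on the saturated chain carbon bound to an oxygen on an aromatic ring does not by itself bring a lower number, since the 3-(trifluoromethyl)phenyl compound stands well apart from the 2-cyanophenyl compound, with an at least 10-fold higher number from compound 3 to compound 4 (1.00 log units; beyond the scatter). Compound 3 therefore remains the only one of the four with a lower number beyond the scatter relative to compound 1, while the step to compound 4 reads an at least 1.4-fold higher number from compound 1 to compound 4 (0.17 log units; that floor lies within the scatter), and the size of the step from compound 2 to compound 4 cannot be read, so that compound 4 cannot be placed in order against compound 1 or compound 2.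

How far compound 4 lies past the limit stays open, and the nitrile appears only as 2-cyanophenyl, so the compounds shown cannot separate the nitrile itself from where it sits on the ring. Going by these compounds, whether an amine, a carboxylic acid or an amide on the same aryl ring would follow compound 3 or compound 4 also stays open.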